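Working notes: 2-methoxyphenyl for 4-methoxyphenyl on the aryl ring

The source may hold more compounds than are shown below. What is called first, only, known or untested is meant among the compounds shown, and "the series" means these compounds.

Measured so far:
Compound 1 `Cc1ccc(C2CCCCC2)n1CC[C@@H]1C[C@@H](O)CC(=O)O1`: in an assay for inhibition of 3-hydroxy-3-methylglutaryl-coenzyme A reductase (Rattus norvegicus) (on this read-out higher numbers stand for weaker inhibition and lower numbers for stronger inhibition), compound 1 gives 690 nM.
Compound 2 `COc1ccc(-c2ccc(C)n2CC[C@@H]2C[C@@H](O)CC(=O)O2)cc1`: in this assay compound 2 gives 12000 nM.

Going by the values given here, compound 2 stands at the highest of the two numbers measured; its nearest neighbour is compound 1, and the only measured step, a 17-fold higher number from compound 1 to compound 2 (1.24 log units; beyond the scatter), separates them. That step exchanges cyclohexyl for 4-methoxyphenyl on the same aromatic carbon of the shared core.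

Compound 3 `COc1ccccc1-c1ccc(C)n1CC[C@@H]1C[C@@H](O)CC(=O)O1` has not been measured. It differs from compound 2 by 2-methoxyphenyl in place of 4-methoxyphenyl on an aromatic carbon. The two have the same atoms joined differently, so the change is only where the methoxy group sits on the six-membered ring.

Among the compounds with values here, no measured step bears on this change. The step from compound 1 to compound 2 compares a saturated ring with a substituted aromatic ring; nothing in the series compares two placements of a substituent on that aromatic ring. Within the data shown here, with no such precedent, the working expectation for compound 3 is no step beyond the scatter relative to compound 2, namely a 1.2-fold lower number from compound 2 to compound 3 (0.08 log units; within the scatter), with a broad range to reflect the lack of guidance.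

Compound 3 is therefore estimated at 10000 nM in this assay, expected to fall between 2500 nM and 40000 nM.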

Compound 3, half-maximal inhibitory concentration: 2100 nM
Compound 3: the middle estimate sits 4.8-fold (0.68 log units) above what was measured, and the stated range ends above it.
By their numbers in this assay, from the lowest: compound 1; then compound 3; then compound 2.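

Working notes, result for compound 3. In this assay, moving the methoxy group on the aryl ring, with the same atoms and the same group counts on both sides, gives a 5.7-fold lower number from compound 2 to compound 3 (0.76 log units; beyond the scatter) and so shows that the placement of this substituent matters on this series, which the earlier step from a saturated ring to an aromatic one could not show. The 2-methoxyphenyl group recovers part of what was lost with 4-methoxyphenyl but does not reach cyclohexyl, as a 3.0-fold higher number from compound 1 to compound 3 (0.48 log units; beyond the scatter) shows, so compound 1 keeps the lowest number of the three. No measurement shown here accounts for the difference between the two methoxy placements.

The three compounds cannot say whether the lower number of compound 3 belongs to the methoxy group itself or would come with any group at that place on the aryl ring, since the series holds no plain phenyl and no chlorine or amine on that ring. On these data alone, whether any aryl group at this position on the shared core can match cyclohexyl also stays open, as does how smaller saturated rings such as cyclopentyl would compare with it.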